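The source may report more compounds than this note shows. Statements on the series, on what has been measured and on what is new or still open speak of the compounds shown alone.

Of the compounds shown here, two sharing one core have so far been measured in a functional assay on OVCAR-3 cells (Homo sapiens) for inhibition, read by MTT assay, with a stated time of 24 h; a lower number here means a stronger inhibitor, a higher number a weaker inhibitor. Compound 1 `CC1(C)[C@H]2CC[C@]1(C)N(Cc1cn(-c3cccc(F)c3)nn1)C(=O)C2` gives 430 nM, while compound 2 `CC1(C)[C@H]2CC[C@]1(C)N(Cc1cn(-c3ccc(F)cc3)nn1)C(=O)C2` gives 200 nM, the lower of the two numbers and therefore the stronger inhibitor of this pair. The next compound, compound 3 `CC1(C)[C@H]2CC[C@]1(C)N(Cc1cn(-c3ccccc3Cl)nn1)C(=O)C2`, keeps the core but has 2-chlorophenyl in place of 4-fluorophenyl on an aromatic nitrogen. Among the measured compounds shown here, only one measured step bears on this change: a 2.2-fold lower number from compound 1 to compound 2 (0.33 log units; beyond the scatter). That modest step exchanged 3-fluorophenyl for 4-fluorophenyl at the same place, so it is only a loose guide. For the measured compounds named here, no measured compound carries a chlorophenyl group, and no measured step shows what exchanging fluorine for chlorine does. Compound 3 gives up the 4-fluorophenyl group of compound 2, so a modest rise toward the number of compound 1, at 430 nM, seems more likely than a further fall, though the uncertainty is wide. The expected change is a 2.0-fold higher number from compound 2 to compound 3 (0.30 log units; within the scatter). For compound 3, the estimated value is 400 nM, with an expected range from 130 nM to 1200 nM.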

Compound 3, half-maximal inhibitory concentration: 40 nM
Beside the measured number, compound 3's estimate is 10-fold (1.00 log units) above it; the whole stated range lies above it.
By their numbers in this assay, from the lowest: compound 3; then compound 2; then compound 1.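

The aromatic group on this nitrogen of the five-membered ring can move the result in this assay much further than the earlier comparison showed, where the exchange of 3-fluorophenyl for 4-fluorophenyl gave a 2.2-fold lower number from compound 1 to compound 2 (0.33 log units; beyond the scatter) and only a modest shift. Bringing in 2-chlorophenyl gives a 5.0-fold lower number from compound 2 to compound 3 (0.70 log units; beyond the scatter) when it replaces 4-fluorophenyl and an 11-fold lower number from compound 1 to compound 3 (1.03 log units; beyond the scatter) when it replaces 3-fluorophenyl, which makes compound 3 the strongest inhibitor of the three and shows that a halogen-bearing phenyl need not be tied to fluorine for a low number. Nothing shown explains why this exchange lowers the number so far.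

Compound 3 differs from compound 1 and compound 2 in both the halogen and its place on the phenyl ring, so these compounds cannot show how much of the step belongs to each change. As far as these compounds go, how an unsubstituted phenyl, or a phenyl carrying bromine, methyl, methoxy or an amine, would read at this nitrogen also remains open.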